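Propyl in Place of Methyl on the Shared Core

The source may report more compounds than this note shows. Statements on the series, on what has been measured and on what is new or still open speak of the compounds shown alone.

Measured so far in a functional assay on KB cells (Homo sapiens) for cytotoxicity; a higher number here means a weaker inhibitor, a lower number a stronger inhibitor:
compound 1, `C=CCn1cc(C(N)=S)c2c(N)ncnc21`: 19000 nM
compound 2, `Cn1cc(C(N)=O)c2c(N)ncnc21`: > 100000 nM
compound 3, `Cn1cc(C(=N)S)c2c(N)ncnc21`: 15000 nM

Compound 2 reaches only a limit of this assay, > 100000 nM, so its place is known just as a bound (the limit of > 100000 nM in this assay, at which 1 of the 3 values shown sits). Among the compounds with values here, the one measured step that starts from compound 2 is an at least 6.6-fold lower number from compound 2 to compound 3 (0.82 log units; beyond the scatter), a change on an aromatic carbon, not where compound 4 differs. Compound 4, `CCCn1cc(C(N)=O)c2c(N)ncnc21`, differs from compound 2 by ethyl in place of hydrogen on a saturated chain carbon bound to an aromatic nitrogen. Within the data shown here, no measured pair changes only the group bound to the aromatic nitrogen; compound 1 and compound 3 carry different such groups but also differ elsewhere, and their values in this assay sit within the scatter of each other. For compound 4 the step is therefore expected to be a number no higher from compound 2 to compound 4 (the limit leaves the size open), that is, none beyond the scatter. Compound 4 is estimated at 100000 nM, between 30000 nM and 300000 nM.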

Compound 4, half-maximal inhibitory concentration: 100000 nM
Beside the measured number, compound 4's estimate shows no gap at the digits printed, and the stated range covers the measured number.
By their numbers in this assay, from the lowest: compounds 3 and 1 (each within the scatter of the next); then compound 4.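

Within the data shown here, the change from methyl to propyl is the first measured change at this place alone, on a saturated chain carbon bound to an aromatic nitrogen, and in this assay it reads as a number no higher from compound 2 to compound 4 (the limit leaves the size open). In this assay compound 4 gives 100000 nM. Compound 2 has only a limit, > 100000 nM. The size of this step therefore cannot be read: the limit of > 100000 nM in this assay, at which 1 of the 4 values shown sits.

The compounds shown leave open how a longer chain, or a chain ending in an amine or a carboxylic acid, would read at this place. They also leave open whether methyl to propyl reads the same on a core that carries sulfur in place of the carbonyl oxygen.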